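Trimming the amine substituent on a pyrrolidine diol

The source may report more compounds than this note shows. Statements on the series, on what has been measured and on what is new or still open speak of the compounds shown alone.

Measured compounds:
compound 1 `OC[C@H](NC[C@H]1N[C@H](CO)[C@H](O)[C@@H]1O)c1ccccc1` — 11800 nM
compound 2 `C[C@H](O)NC[C@H]1NC[C@H](O)[C@@H]1O` — 683000 nM

Of the compounds shown here, two have been measured in an assay on isolated protein for inhibition of alpha-mannosidase 2 (Homo sapiens); a lower number here means a stronger inhibitor, a higher number a weaker inhibitor. Compound 1 `OC[C@H](NC[C@H]1N[C@H](CO)[C@H](O)[C@@H]1O)c1ccccc1` carries a larger, hydroxylated benzylic substituent on the amine and a further hydroxymethyl on the core; in this assay compound 1 gives 11800 nM. Compound 2 `C[C@H](O)NC[C@H]1NC[C@H](O)[C@@H]1O` is a smaller relative and gives 683000 nM, the highest number of the two and far weaker than compound 1, the difference between them lying well beyond the scatter.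

The step under examination leads from compound 2 to compound 3 `NC[C@H]1NC[C@H](O)[C@@H]1O`, which has not yet been measured. The change is hydrogen in place of 1-hydroxyethyl on an amine nitrogen. For the measured compounds named here, no measured pair isolates this change, so the two values so far only show that a larger, more elaborate substituent on the amine goes with a much lower number.

Because compound 2 gives 683000 nM and the group removed is small, the author expects only a modest step of a 1.3-fold higher number from compound 2 to compound 3 (0.12 log units; within the scatter), possibly none beyond the scatter, leaning toward a somewhat higher number. Compound 3 is therefore estimated at 900000 nM, within 300000 nM to 2700000 nM.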

Compound 3, inhibition constant: 1310000 nM
Compound 3: middle estimate off by 1.5-fold (0.16 log units), on the low side; measured number inside the range.
By their numbers in this assay, from the lowest: compound 1; then compounds 2 and 3 (each within the scatter of the next).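

In this assay, for the compounds shown here, the exchange of 1-hydroxyethyl for hydrogen on an amine nitrogen gives a 1.9-fold higher number from compound 2 to compound 3 (0.28 log units; within the scatter) and this is the first pair in which a single change can be read on its own. At this position, the whole group, with its oxygen and its defined stereocentre, can go without a shift that stands clear of the usual spread of repeated measurements, so this pair does not show that 1-hydroxyethyl matters here. No measurement is available that could explain this result.

Compound 1 at 11800 nM differs from compound 2 and compound 3 in more than one place, so the compounds shown leave open whether its benzylic substituent, the further hydroxymethyl on its core or both together lie behind its value. Also open, as far as these compounds go, is how a longer chain, a benzyl group or a carboxylic acid on the same amine nitrogen would read in this assay against the hydrogen of compound 3 and the 1-hydroxyethyl of compound 2.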